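This account rests on a few compounds, and the source may have more. Where it says the series, first, only, none or still open, it means among the compounds named here.

Compound 1 `CC(C)OC(=O)Nc1c(N)nc(-c2nn(Cc3ccccc3F)c3ncccc23)nc1N` gives 0.8 uM in an assay on cells for activation of Guanylate cyclase soluble subunit alpha-1 (Rattus norvegicus), read by cGMP accumulation and immunoassay, with a stated time of 10 min (a higher number here means that more compound is needed for the effect, a lower number that less compound is needed), the highest of the two numbers measured; its nearest neighbour, compound 2 `Nc1nc(-c2nn(Cc3ccccc3F)c3ncccc23)nc(N)c1N1CCOC1=O`, gives 0.3 uM, a modest step of a 2.7-fold lower number from compound 1 to compound 2 (0.43 log units; beyond the scatter) brought by the 2-oxo-1,3-oxazolidin-3-yl in place of the (isopropoxycarbonyl)amino group. Compound 3 `Nc1nc(-c2nn(Cc3ccccc3F)c3ncccc23)nc(N)c1N1C[C@H](C(F)(F)F)OC1=O` carries the change (a group of 10 heavy atoms (4 carbon, 1 nitrogen, 2 oxygen, 3 fluorine; one five-membered non-aromatic ring with 2 hetero atoms) in place of a group of 7 heavy atoms (4 carbon, 1 nitrogen, 2 oxygen; no ring), on an aromatic carbon), a five-membered ring with a trifluoromethyl group and one defined stereocentre entering at the same aromatic carbon. The step from compound 1 to compound 2 bears on it directly, so a lowering of similar size is expected, a 2.7-fold lower number from compound 1 to compound 3 (0.43 log units; beyond the scatter). For compound 3 the estimate in this assay is 0.3 uM, within 0.1 uM to 0.9 uM.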

Compound 3, minimum effective concentration: 0.2 uM
For compound 3 the middle estimate is 1.5-fold (0.18 log units) above the measured one; the measured number falls inside the stated range.
By their numbers in this assay, from the lowest: compounds 3 and 2 (each within the scatter of the next); then compound 1.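

In this assay, the five-membered ring bearing trifluoromethyl also gives a lower number than the open (isopropoxycarbonyl)amino group on the aromatic carbon ortho to two amino groups (a 4.0-fold lower number from compound 1 to compound 3 (0.60 log units; beyond the scatter)). Trifluoromethyl in place of hydrogen on the saturated ring carbon gives a step that cannot be told from scatter (a 1.5-fold lower number from compound 2 to compound 3 (0.18 log units; within the scatter)). No measurement offered here accounts for either step. Still open, as far as these compounds go, is how the opposite configuration at the stereocentre would read, and whether a methyl group on that ring carbon or a morpholine at the aromatic carbon would give a similar number.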